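Swapping a Phenyl for a Thiophene in a Tropane Series

A few compounds are considered here, and "the series" means these few. Any claim that something is new, unique, unknown or untested is made for them only; others in the source may bear on it.

The shared core in this set is a bicyclic amine carrying a methyl ester, with a long aromatic arm hung from one carbon. Compound 1 `COC(=O)C1C2CCC3CCC1N(C/C2=C\c1ccc(-c2ccc(C)cc2)cc1)C3` is measured in an assay with Norepinephrine transporter (Rattus norvegicus) as the target (on this read-out higher numbers stand for weaker inhibition and lower numbers for stronger inhibition), at 22.7 nM. Compound 2 `COC(=O)C1C2CCC3CCC1N(C/C2=C\c1ccc(-c2ccc(C#N)cc2)cc1)C3` gives 32.4 nM in this assay. Within the data shown here, the only measured step, a 1.4-fold higher number from compound 1 to compound 2 (0.15 log units; within the scatter), shows that a cyano in place of methyl on an aromatic carbon changes little. Compound 1 therefore holds the lowest number of the two, though its neighbour compound 2 sits within the scatter of it.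

Compound 3 `COC(=O)C1C2CCC3CCC1N(C/C2=C\c1ccc(-c2ccc(C)s2)cc1)C3` has not yet been measured. It differs from compound 1 by 5-methylthiophen-2-yl in place of 4-methylphenyl on an aromatic carbon. Among the measured compounds shown here, no measured step here exchanges one aromatic ring for another, so the single step from compound 1 to compound 2 bears only loosely on it. The expected outcome is a step of about a 1.1-fold higher number from compound 1 to compound 3 (0.04 log units; within the scatter), that is, no clear shift beyond the scatter. Compound 3 is estimated at 25 nM, with a likely range from 8 nM to 80 nM.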

Compound 3, inhibition constant: 22.5 nM
For compound 3 the middle estimate is 1.1-fold (0.05 log units) above the measured one; measured number inside the range.
By their numbers in this assay, from the lowest: compounds 3, 1 and 2 (each within the scatter of the next).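

In this assay the result a 1.0-fold lower number from compound 1 to compound 3 (0.00 log units; within the scatter) shows that this position tolerates a change of the ring itself, not only of the group at its far end. A five-membered aromatic ring with a sulfur atom can stand in for the six-membered carbon ring here without any shift beyond the scatter. The exchange of 4-cyanophenyl for 5-methylthiophen-2-yl gives a 1.4-fold lower number from compound 2 to compound 3 (0.16 log units; within the scatter) and likewise stays within the scatter, and nothing further is available to explain why these rings read alike.

Still open, from the compounds shown here alone, is whether the numbers would hold with an amine or a carboxylic acid at the end of the arm. A pyridine ring or a thiophene carrying a longer chain in place of the methyl is equally untested by the compounds shown.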